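Tert-butyl in place of phenoxy on the urea aryl ring

The compounds below may be only part of what the source reports. "The series", "measured", "known", "first", "only" and "open" are said of these compounds alone.

Compound 2 `CN(C)CCC(NC(=O)Nc1ccc(Oc2ccccc2)cc1)c1ccc(Cl)cc1` gives 108% in an assay on NIH3T3 cells with Urotensin-2 receptor (Homo sapiens) as the target; a higher number here means a larger maximal response, a lower number a smaller maximal response. Compound 1 `CN(C)CCC(NC(=O)Nc1ccc(C(F)(F)F)cc1)c1ccc(Cl)cc1` gives 105% in this assay, and the two sit within the scatter of each other, the step being a number 3 percentage points higher from compound 1 to compound 2 (within the scatter). Compound 3 `CN(C)CCC(NC(=O)Nc1ccc(C(C)(C)C)cc1)c1ccc(Cl)cc1` carries the change (tert-butyl in place of phenoxy on an aromatic carbon). Going by the values given here, the only step that bears on it is the exchange at the same aromatic carbon from compound 1 to compound 2, which stayed within the scatter, so no movement beyond the scatter is expected in this assay. Compound 3 is therefore estimated at 105%, within 90% to 120%. The expected step is a number 3 percentage points lower from compound 2 to compound 3 (within the scatter).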

Compound 3, largest response reached (reported as efficacy), in percent of the reference or control that the assay uses: 103%
The estimate for compound 3 lay 2 percentage points above the measured number; measured number inside the range.
By their numbers in this assay, from the lowest: compounds 3, 1 and 2 (each within the scatter of the next).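

With tert-butyl at this aromatic carbon, this assay gives a number 5 percentage points lower from compound 2 to compound 3 (within the scatter) and a number 2 percentage points lower from compound 1 to compound 3 (within the scatter). Removing the aromatic ring and the hydrogen-bond acceptor of phenoxy therefore shifts the maximal response by no more than the scatter, and a group with no ring serves here as well as one with a ring. Nothing at hand explains this flat result.

As far as these compounds go, whether an amine or a carboxylic acid at this carbon would move the response beyond the scatter remains open. So does the effect of changes elsewhere on the shared core.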